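Ring replacement at the amide carbonyl in a sulfone series

The compounds below may be only part of what the source reports. "The series", "measured", "known", "first", "only" and "open" are said of these compounds alone.

Measured compounds:
- compound 1 `CCC[C@]1(C(=O)N2CC[C@](c3ccc(C(F)(C(F)(F)F)C(F)(F)F)cc3)(S(=O)(=O)c3ccc(F)cc3)C2)CC[C@H](C(=O)O)CC1`: in an ADME assay on microsomes from liver (Mus musculus) for metabolic stability, with a stated time of 10 min (a lower number here means that less of the compound is left, a higher number that more of the compound is left), compound 1 gives "not determined" (no result reported)
- compound 2 `COC(=O)[C@H]1CC[C@H](C(=O)N2CC[C@](c3ccc(C(F)(C(F)(F)F)C(F)(F)F)cc3)(S(=O)(=O)c3ccc(F)cc3)C2)CC1`: compound 2 gives "not determined" (no result reported)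
- compound 3 `O=C(C1CCS(=O)(=O)C1)N1CC[C@](c2ccc(C(F)(C(F)(F)F)C(F)(F)F)cc2)(S(=O)(=O)c2ccc(F)cc2)C1`: compound 3 gives 78%; 96% (2 entries)

Compound 1 stands without any number in this assay, and the same holds for compound 2. Only compound 3 has results, and its two entries (the several entries of compound 3 in this assay, 78%; 96% (2 entries)) lie within the usual scatter of each other.

Compound 4 `O=C(C1CCS(=O)(=O)CC1)N1CC[C@](c2ccc(C(F)(C(F)(F)F)C(F)(F)F)cc2)(S(=O)(=O)c2ccc(F)cc2)C1` carries the change (1,1-dioxothian-4-yl in place of 4-carboxy-1-propylcyclohexyl on a carbonyl carbon). For the measured compounds named here, no measured step covers this change, so no size or direction can be read from the data; with compound 1 unmeasured, the only anchor is compound 3, whose group differs from that of compound 4 by one ring member.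

Compound 4 is expected to give 85% in this assay, estimated between 65% and 99%.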

Compound 4, percent of the compound remaining: 96%
The estimate for compound 4 lay 11 percentage points below the measured number; low and high end bracket the measured number.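

In this assay compound 1 stands at "not determined" (no result reported) and compound 4 at 96%, so no step can be read between them. Open remains how 1,1-dioxothian-4-yl compares with 4-carboxy-1-propylcyclohexyl on that carbonyl carbon.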